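The compounds below may be only part of what the source reports. "The series", "measured", "known", "first", "only" and "open" are said of these compounds alone.

Measured compounds:
compound 1, `Nc1nn(C(=O)Nc2ccc(Cc3ccccc3)cc2)c2ccccc12`, in a functional assay on TK-10 cells (Homo sapiens) for antiproliferative activity, read by sulforhodamine B assay, with a stated time of 48 h; on this read-out lower numbers stand for stronger inhibition of growth and higher numbers for weaker inhibition of growth: > 100000 nM

For compound 1 the value is a limit of the assay and not a number.

compound 2, `Nc1nn(C(=O)Nc2ccc(Cc3ccccc3)cc2)c2ccc(Cl)cc12`, in this assay: 38700 nM

Compound 2 carries the only number shown, the one further value being a limit, so within this pair it stands as the single measured point. The step of an at least 2.5-fold lower number from compound 1 to compound 2 (0.41 log units; beyond the scatter) lies beyond the scatter; its size is bounded on one side by the limit of > 100000 nM in this assay, at which 1 of the 2 values shown sits.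

Compound 3, `Nc1ccc2c(c1)c(N)nn2C(=O)Nc1ccc(Cc2ccccc2)cc1`, differs from compound 2 by amino in place of chloro on an aromatic carbon. Among the measured compounds shown here, the one measured step, an at least 2.5-fold lower number from compound 1 to compound 2 (0.41 log units; beyond the scatter), concerns chloro against hydrogen and bears only loosely on an exchange of chloro for amino; no measured pair shows amino at this position. In this assay the expectation is a step of modest size at most, direction uncertain, with a somewhat higher number than for compound 2 held slightly more likely. The estimate for compound 3 is 50000 nM, within a range from 15000 nM to 160000 nM, which means an expected step of a 1.3-fold higher number from compound 2 to compound 3 (0.11 log units; within the scatter).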

Compound 3, concentration for total growth inhibition: 46000 nM
Beside the measured number, compound 3's estimate is 1.1-fold (0.04 log units) above it; low and high end bracket the measured number.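

In this assay, the exchange of chloro for amino on this aromatic carbon gives a 1.2-fold higher number from compound 2 to compound 3 (0.08 log units; within the scatter), so compound 2 and compound 3 cannot be told apart here, even though the two groups differ in their hydrogen-bond donor and acceptor counts. The new comparison with hydrogen gives an at least 2.1-fold lower number from compound 1 to compound 3 (0.33 log units; beyond the scatter), so a step beyond the scatter is no longer seen with chloro alone but also with amino at the same carbon, and in these three compounds either group separates from hydrogen. Compound 1 stands at a limit of the assay and not at a number, so both steps from it have a size that is fixed on one side only: the limit of > 100000 nM in this assay, at which 1 of the 3 values shown sits.

The three compounds do not show whether other groups on this carbon, such as methoxy, nitro or a carboxylic acid, would match chloro and amino or move the number further from that of compound 1. They also leave open whether a substituent on another carbon of the same ring would give a comparable step from hydrogen.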